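A Chloro-for-Methyl Swap Repeated on a Second Core

This account rests on a few compounds, and the source may have more. Where it says the series, first, only, none or still open, it means among the compounds named here.

Of the compounds shown here, three have so far been measured for their effect on the growth of a lung cancer cell line, and a fourth awaits measurement. Compound 1 `CCOC(=O)c1c(-c2c(Cl)c3cc(C)ccc3oc2=O)nn(-c2cccc(C)c2)c1C(=O)OCC` carries a 3-methylphenyl group on the shared core; in a functional assay on A549 cells (Homo sapiens) for cytotoxicity, read by MTT assay, with a stated time of 48 h (a higher number here means a weaker inhibitor, a lower number a stronger inhibitor), compound 1 gives 115000 nM. Compound 2 `CCOC(=O)c1c(-c2c(Cl)c3cc(C)ccc3oc2=O)nn(-c2cccc(Cl)c2)c1C(=O)OCC` differs from compound 1 only by chloro in place of methyl on an aromatic carbon. In this assay compound 2 gives 128000 nM. The step between them is small: a 1.1-fold higher number from compound 1 to compound 2 (0.05 log units; within the scatter).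

Compound 3 `CCOC(=O)c1c(-c2cc3ccc(OC)cc3oc2=O)nn(-c2cccc(C)c2)c1C(=O)OCC` is built on a different core; how the two cores differ is not broken down here. In this assay compound 3 gives 171000 nM, a number that sits within the scatter of both compound 1 and compound 2, so no order among the three can be claimed.

Compound 4 `CCOC(=O)c1c(-c2cc3ccc(OC)cc3oc2=O)nn(-c2cccc(Cl)c2)c1C(=O)OCC` has not yet been measured. It differs from compound 3 by chloro in place of methyl on an aromatic carbon, the same change that separates compound 2 from compound 1, made at the same place on the same kind of ring. Since that change left the number essentially unmoved from compound 1 to compound 2, compound 4 is expected to behave like compound 3, with an expected step of a 1.1-fold higher number from compound 3 to compound 4 (0.05 log units; within the scatter). The expectation rests on a single earlier instance on another core. Compound 4 is therefore estimated at 190000 nM, with a plausible range from 100000 nM to 350000 nM.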

Compound 4, half-maximal inhibitory concentration: 221000 nM
For compound 4 the middle estimate is 1.2-fold (0.07 log units) below the measured one; the measured number falls inside the stated range.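

In this assay, putting chloro in place of methyl on the core of compound 3 gives a 1.3-fold higher number from compound 3 to compound 4 (0.11 log units; within the scatter), so the swap from 3-methylphenyl to 3-chlorophenyl leaves the number as unmoved here as it did on the core of compound 1. Set side by side, the two instances do not differ: the same change on two cores in this assay, a 1.1-fold higher number (0.05 log units; within the scatter) from compound 1 to compound 2 and a 1.3-fold higher number (0.11 log units; within the scatter) from compound 3 to compound 4, 1.2-fold (0.06 log units) apart, within the scatter of two such steps. This shows that, in this small set, the swap carries from one core to the other as a change with no readable effect, but it does not show that a real shift of a shared size is being transferred, since both steps are within the scatter, and two cores in a single cell line say nothing about any further core.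

Going by these compounds, all four compounds carry only methyl or chloro on this phenyl ring, so it remains open whether an amine, a hydroxyl or a longer chain at that place would move the number beyond the scatter. The two ethyl esters also stand unchanged throughout, which leaves open what a carboxylic acid or an amide in their place would do in this cell line.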